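This account rests on a few compounds, and the source may have more. Where it says the series, first, only, none or still open, it means among the compounds named here.

Compound 1 `O=C1CCC(CSc2nc(-c3ccccc3)c(-c3ccccc3)[nH]2)N1` and compound 2 `c1ccc(-c2nc(SCC3OCCO3)[nH]c2-c2ccccc2)cc1` share one core and differ only in the group on a saturated chain carbon bound to a sulfur. In an assay on microsomes from liver for inhibition of sterol O-acyltransferase 1 (Rattus norvegicus) (a lower number here means a stronger inhibitor, a higher number a weaker inhibitor), compound 1 gives 360 nM, while compound 2 gives 530 nM, so the step of a 1.5-fold higher number from compound 1 to compound 2 (0.17 log units; within the scatter) leaves compound 2 beside compound 1 rather than apart from it. Compound 3 `c1ccc(CSc2nc(-c3ccccc3)c(-c3ccccc3)[nH]2)cc1` carries phenyl in place of 1,3-dioxolan-2-yl on a saturated chain carbon bound to a sulfur. Because a 1.5-fold higher number from compound 1 to compound 2 (0.17 log units; within the scatter) stayed within the scatter, the step of a 1.3-fold lower number from compound 2 to compound 3 (0.12 log units; within the scatter) is expected to be small as well. Compound 3 is therefore estimated at 400 nM, with a likely range from 150 nM to 1200 nM.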

Compound 3, half-maximal inhibitory concentration: 290 nM
The estimate for compound 3 lay 1.4-fold (0.14 log units) above the measured number, within the range that was stated.
By their numbers in this assay, from the lowest: compounds 3, 1 and 2 (each within the scatter of the next).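

The step of a 1.8-fold lower number from compound 2 to compound 3 (0.26 log units; within the scatter) swaps a non-aromatic ring holding 2 hydrogen-bond acceptors for an aromatic ring of carbon only with none, and the step of a 1.2-fold lower number from compound 1 to compound 3 (0.09 log units; within the scatter) also stays small. In this assay, this position on a saturated chain carbon bound to a sulfur therefore accepts three differently built rings without leaving the scatter, now including one with no hetero atoms. Nothing available explains why these groups read alike. As far as these compounds go, whether an amine or a carboxylic acid here would also stay within the scatter remains open.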